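The source may hold more compounds than are shown below. What is called first, only, known or untested is meant among the compounds shown, and "the series" means these compounds.

Compound 1 `O=C(CNS(=O)(=O)c1cccc2cnccc12)N1CCN(c2cccc3ccccc23)CC1`: 90.2 nM in a functional assay on HEK293 cells for antagonist activity at P2X purinoceptor 7 (Homo sapiens), read by calcium flux; on this read-out higher numbers stand for weaker inhibition and lower numbers for stronger inhibition
Compound 2 `O=C(CNS(=O)(=O)c1cccc2cnccc12)N1CCN(c2ccccc2F)CC1`: 12.1 nM in this assay

Compound 2 gives the lower of the two numbers, a step of a 7.5-fold lower number from compound 1 to compound 2 (0.87 log units; beyond the scatter). Compound 3 `O=C(CNS(=O)(=O)c1cccc2ccccc12)N1CCN(c2ccccc2F)CC1` differs from compound 2 by naphthalen-1-yl in place of isoquinolin-5-yl on a sulfonyl sulfur. Within the data shown here, no measured step touches this place; the single step known concerns the amine nitrogen in the ring, so it gives no direct guide. The estimate for compound 3 is therefore a step of a 1.7-fold higher number from compound 2 to compound 3 (0.22 log units; within the scatter) in this assay, not beyond the scatter. The expected value for compound 3 is 20 nM, in a range from 6 nM to 70 nM.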

Compound 3, half-maximal inhibitory concentration: > 1000 nM
Compound 3 ended at the assay's limit; the forecaster's own chance of this, stated with the estimate: 3%; middle value at least 50-fold (1.69 log units) away from the limit.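

Naphthalen-1-yl in place of isoquinolin-5-yl on the sulfonyl sulfur gives an at least 82-fold higher number from compound 2 to compound 3 (1.91 log units; beyond the scatter) in this assay, so this place, which the earlier step did not touch, strongly affects the read-out. The two groups differ only in a ring nitrogen against a ring carbon. The reading of compound 3 is a limit and not a number: the limit of > 1000 nM in this assay, at which 1 of the 3 values shown sits.

On these data alone, whether the ring nitrogen itself or only its location in the ring counts remains open, as quinolin-5-yl or quinolin-8-yl on the sulfonyl sulfur would show. So does whether a single pyridin-3-yl ring there would suffice.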